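The source may hold more compounds than are shown below. What is called first, only, known or untested is meant among the compounds shown, and "the series" means these compounds.

Measured compounds in an in vitro functional assay on HEK285-7 cells for antagonist activity at prostaglandin D2 receptor 2 (Homo sapiens), read by BRET and beta-arrestin recruitment; on this read-out lower numbers stand for smaller maximal responses and higher numbers for larger maximal responses:
- compound 1 `N#Cc1ccc(-c2nc(C(c3ccc(F)cc3)c3ccc(F)cc3)sc2CC(=O)O)cc1` gives 30%
- compound 2 `COc1ccc(C(c2ccccc2)c2nc(-c3ccc(Cl)cc3)c(CC(=O)O)s2)cc1` gives 80%
- compound 3 `O=C(O)Cc1sc(C(c2ccccc2)c2ccccc2)nc1-c1ccccc1` gives 80%

Compound 1 holds the lowest maximal response of the three. Compound 2 sits higher, and compound 3 sits above compound 1 as well; both gaps lie beyond the usual scatter. Compounds 2 and 3 are within the scatter of each other, so no order is drawn between them.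

The next compound, compound 4 `Cc1cc(-c2nc(C(c3ccc(F)cc3)c3ccc(F)cc3)sc2CC(=O)O)cnc1N`, is not yet measured in this assay. It differs from compound 1 in one place: 6-amino-5-methylpyridin-3-yl in place of 4-cyanophenyl on an aromatic carbon. The 4-cyanophenyl goes, a 6-amino-5-methylpyridin-3-yl comes in, and the rest of the shared core is untouched.

No measured step connects any pair of these compounds, so the effect of this change has to be estimated from the spread shown. The three aryl groups at this position give maximal responses that differ beyond scatter, which argues that the exchange matters. Compound 4 is expected to move upward from compound 1 by a moderate step, a number 25 percentage points higher from compound 1 to compound 4 (beyond the scatter), but with wide uncertainty. The estimate for compound 4 is 55%, with a range from 25% to 85%.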

Compound 4, largest response reached (reported as efficacy), in percent of the reference or control that the assay uses: 80%
Compound 4: the middle estimate sits 25 percentage points below what was measured; the measured number falls inside the stated range.
By their numbers in this assay, from the lowest: compound 1; then compounds 2, 3 and 4 (each within the scatter of the next).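

In this assay, among these compounds, the exchange of 4-cyanophenyl for 6-amino-5-methylpyridin-3-yl gives the first step that changes one place only: a number 50 percentage points higher from compound 1 to compound 4 (beyond the scatter) with the rest of the shared core untouched. Among the compounds shown here, the position next to the ring nitrogen, on the ring atom next to the one bearing the carboxymethyl group, therefore responds on its own to the aryl group placed there. The entering group brings a ring hetero atom and 1 hydrogen-bond donor and loses the nitrile, but no measurement shown here gives a reason for the step.

The compounds shown do not separate the contributions of the amine, the methyl and the ring nitrogen. A 6-aminopyridin-3-yl or a 4-aminophenyl at the same carbon would bear on that question.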